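Moving a methyl from one ring position to another

This account rests on a few compounds, and the source may have more. Where it says the series, first, only, none or still open, it means among the compounds named here.

Measured in a functional assay on PC-3 cells (Homo sapiens) for cytotoxicity, read by sulforhodamine B assay; on this read-out lower numbers stand for stronger inhibition of growth and higher numbers for weaker inhibition of growth:
- compound 1, `COc1cccc(OC)c1OCCNCCOc1ccccc1OCc1ccccc1Cl`: 17800 nM
- compound 2, `COc1cccc(OC)c1OCCNCCOc1ccccc1OCc1cccc(Cl)c1`: 20400 nM
- compound 3, `COc1cccc(OC)c1OCCNCCOc1ccccc1OCc1ccccc1C`: 33900 nM

Compound 3 gives the highest of the three numbers in this assay, but its distance to the others is small: a 1.9-fold higher number from compound 1 to compound 3 (0.28 log units; within the scatter) and a 1.7-fold higher number from compound 2 to compound 3 (0.22 log units; within the scatter), so the three compounds cannot be told apart on these data.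

Compound 4, `COc1cccc(OC)c1OCCNCCOc1ccccc1OCc1cccc(C)c1`, is not yet measured. It differs from compound 3 in one respect: 3-methylphenyl in place of 2-methylphenyl on a saturated chain carbon bound to an oxygen on an aromatic ring.

The most closely related step among the measured compounds is the same shift of a substituent on the same ring, made with chloro instead of methyl: a 1.1-fold higher number from compound 1 to compound 2 (0.06 log units; within the scatter). That step did not leave the scatter. Nothing else in the data speaks to this change. The expectation for compound 4 in this assay is therefore a number close to that of compound 3, with the step of a 1.1-fold higher number from compound 3 to compound 4 (0.03 log units; within the scatter) not expected to exceed the scatter in either direction. Compound 4 is estimated at 36000 nM, within a range from 18000 nM to 72000 nM.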

Compound 4, concentration for total growth inhibition: 32300 nM
The estimate for compound 4 lay 1.1-fold (0.05 log units) above the measured number; low and high end bracket the measured number.
By their numbers in this assay, from the lowest: compounds 1, 2, 4 and 3 (each within the scatter of the next).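

In this assay, the shift from 2-methylphenyl to 3-methylphenyl on a saturated chain carbon bound to an oxygen on an aromatic ring gives a 1.0-fold lower number from compound 3 to compound 4 (0.02 log units; within the scatter), so the shift stays within the scatter with methyl as it did with chloro. Methyl in place of chloro now has a second reading, a 1.6-fold higher number from compound 2 to compound 4 (0.20 log units; within the scatter), and the pair that differs in both group and ring position gives a 1.8-fold higher number from compound 1 to compound 4 (0.26 log units; within the scatter), which is also within the scatter. The exchange of chloro for methyl reads alike in both ring positions: the same change on two cores in this assay, a 1.9-fold higher number (0.28 log units; within the scatter) from compound 1 to compound 3 and a 1.6-fold higher number (0.20 log units; within the scatter) from compound 2 to compound 4, 1.2-fold (0.08 log units) apart, within the scatter of two such steps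

These four compounds therefore separate neither chloro from methyl nor one ring position from the other. Going by these compounds, whether an amine or a carboxylic acid on that ring, in place of methyl or chloro, would move the number beyond the scatter remains open.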